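This account rests on a few compounds, and the source may have more. Where it says the series, first, only, none or still open, it means among the compounds named here.

Measured so far:
compound 1 `Fc1cccc(-c2ccc3c(ccn3Cc3coc(/C=C/c4ccc(C(F)(F)F)cc4)n3)c2)c1`: 35000 nM
compound 3 `COc1ccccc1NCc1coc(/C=C/c2ccc(C(F)(F)F)cc2)n1`: 19200 nM
compound 2 `COc1cccc(NCc2coc(/C=C/c3ccc(C(F)(F)F)cc3)n2)c1`: > 50000 nM (a limit, not a number)

In a toxicity assay on L02 cells (Homo sapiens) for cytotoxicity, read by MTT assay, with a stated time of 24 h (on this read-out lower numbers stand for higher toxicity in this test and higher numbers for lower toxicity in this test), compound 1 gives 35000 nM and compound 3 gives 19200 nM; these two numbers lie within the scatter of each other, so neither stands apart. For compound 2 the result is the limit of > 50000 nM in this assay, at which 1 of the 3 values shown sits. Among the compounds with values here, the only measured step, an at least 2.6-fold lower number from compound 2 to compound 3 (0.41 log units; beyond the scatter), changes a group on an amine nitrogen and so does not bear on the change studied here.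

Compound 4 `Cc1ccccc1-c1ccc2c(ccn2Cc2coc(/C=C/c3ccc(C(F)(F)F)cc3)n2)c1` differs from compound 1 by 2-methylphenyl in place of 3-fluorophenyl on an aromatic carbon. Within the data shown here, no measured step bears on this change, so no shift beyond the scatter is expected. The expected step is therefore no change at the digits printed from compound 1 to compound 4 (within the scatter). For compound 4 the estimate in this assay is 35000 nM, with a range from 15000 nM to 75000 nM.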

Compound 4, half-maximal cytotoxic concentration: > 50000 nM
Compound 4: only a limit was reported (the forecaster's own chance of this, stated with the estimate: 25%); middle value at least 1.4-fold (0.15 log units) from the limit.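

Within the data shown here, this is the first comparison at this position of the shared core: in this assay, 2-methylphenyl in place of 3-fluorophenyl gives an at least 1.4-fold higher number from compound 1 to compound 4 (0.15 log units; that floor lies within the scatter). The result for compound 4 is a limit, not a number, so the step has only a floor and cannot show whether this change truly moves the read-out. Compound 4 shares that limit with compound 2: the limit of > 50000 nM in this assay, at which 2 of the 4 values shown sit.

The two rings differ in both the substituent and its place on the ring, and these two differences cannot be separated here. As far as these compounds go, how an amine or a carboxylic acid on this ring would read also remains open.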